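From 4-fluorophenyl to 2,6-dimethylphenyl: working notes

The source may report more compounds than this note shows. Statements on the series, on what has been measured and on what is new or still open speak of the compounds shown alone.

The series shares one core and varies the aromatic group on the chain. In a functional assay on HUVEC cells (Homo sapiens) for cytotoxicity (on this read-out higher numbers stand for an effect only at larger amounts of compound and lower numbers for an effect already at smaller amounts), compound 1 (`COC1=C(C)C(=O)/C(=C(O)/C=C/c2ccc(Br)cc2)C(=O)C1(C)C`) gives 3.6 ug/mL and compound 2 (`COC1=C(C)C(=O)/C(=C(O)/C=C/c2cccc(OC)c2)C(=O)C1(C)C`) gives 1.6 ug/mL while compound 3 (`COC1=C(C)C(=O)/C(=C(O)/C=C/c2ccc(F)cc2)C(=O)C1(C)C`) gives 2 ug/mL on the same scale. Compound 3 lies within the scatter of both others, with a 1.3-fold higher number from compound 2 to compound 3 (0.10 log units; within the scatter) and a 1.8-fold lower number from compound 1 to compound 3 (0.26 log units; within the scatter) as its two steps. Only a 2.3-fold lower number from compound 1 to compound 2 (0.35 log units; beyond the scatter) goes beyond the scatter, and that step is modest.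

The next compound is compound 4 (`COC1=C(C)C(=O)/C(=C(O)/C=C/c2c(C)cccc2C)C(=O)C1(C)C`), which differs by 2,6-dimethylphenyl in place of 4-fluorophenyl on a double-bonded chain carbon bound to a double-bonded chain carbon as the change, 2,6-dimethylphenyl in place of 4-fluorophenyl on a double-bonded chain carbon bound to a double-bonded chain carbon. Going by the values given here, no measured compound carries this group, so the three steps offer only indirect guidance. They do show that exchanges of this aromatic group have so far moved this assay only slightly. An expected 1.1-fold higher number from compound 3 to compound 4 (0.04 log units; within the scatter) would stay inside the scatter, so no shift in either direction is anticipated. The estimated value for compound 4 is 2.2 ug/mL within an expected range from 1 ug/mL to 4.5 ug/mL overall.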

Compound 4, concentration for half-maximal effect: 3 ug/mL
Compound 4: middle estimate off by 1.4-fold (0.13 log units), on the low side; the measured number falls inside the stated range.
By their numbers in this assay, from the lowest: compounds 2, 3, 4 and 1 (each within the scatter of the next, the first and the last beyond it).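

With 2,6-dimethylphenyl on a double-bonded chain carbon bound to a double-bonded chain carbon, this assay stays within the scatter of all three earlier compounds (a 1.5-fold higher number from compound 3 to compound 4 (0.18 log units; within the scatter); a 1.9-fold higher number from compound 2 to compound 4 (0.27 log units; within the scatter); a 1.2-fold lower number from compound 1 to compound 4 (0.08 log units; within the scatter)). Going by these compounds alone, a phenyl group with two methyl substituents therefore fits the same narrow range as the phenyl groups with a single bromo, methoxy or fluoro substituent, and compound 4 does not separate compound 1 from compound 2, the only pair whose step lies beyond the scatter. No supporting data bear on why these exchanges move the read-out so little.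

On these data alone, it remains open whether this narrow range extends beyond substituted phenyl groups, for example to a pyridine ring or a longer alkyl chain in place of the aromatic group. A phenyl group carrying an amine or a carboxylic acid is equally untested within the compounds shown here.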